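Methyl for methoxy on a triazole-linked hydroxamic acid

A few compounds are considered here, and "the series" means these few. Any claim that something is new, unique, unknown or untested is made for them only; others in the source may bear on it.

Measured so far:
- compound 1, `COc1ccc(-n2nc(-c3ccccc3)nc2CNc2ccc(C(=O)NO)cc2)cc1`: 127 nM
- compound 2, `COc1ccc(-c2nc(CNc3ccc(C(=O)NO)cc3)n(-c3ccccc3)n2)cc1`: 163 nM

Two compounds have numbers in an assay on Sf9 cells for inhibition of protein deacetylase HDAC6 (Homo sapiens), read by fluorescence, with a stated time of 40 min; a lower number here means a stronger inhibitor, a higher number a weaker inhibitor. Compound 1 gives 127 nM, the lowest of the two. Compound 2, whose structure differs in how the two aryl groups are arranged around the shared core, gives 163 nM; the gap between compound 1 and compound 2 lies within the scatter, so neither can be called the stronger inhibitor.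

Compound 3, `Cc1ccc(-n2nc(-c3ccccc3)nc2CNc2ccc(C(=O)NO)cc2)cc1`, has not been measured. It differs from compound 1 in one place: methyl in place of methoxy on an aromatic carbon. Within the data shown here, no measured pair shows what this exchange does on this core, so the expectation rests on the two numbers alone and on the small size of the change. The account expects no step beyond the scatter: the estimated move from compound 1 to compound 3 is a 1.1-fold higher number from compound 1 to compound 3 (0.04 log units; within the scatter). Compound 3 is therefore estimated at 140 nM, within a range from 60 nM to 330 nM, pending the measurement.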

Compound 3, half-maximal inhibitory concentration: 310 nM
Beside the measured number, compound 3's estimate is 2.2-fold (0.35 log units) below it, within the range that was stated.
By their numbers in this assay, from the lowest: compounds 1, 2 and 3 (each within the scatter of the next, the first and the last beyond it).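

In this assay, among these compounds, the change from 4-methoxyphenyl to 4-methylphenyl gives the first step that can be read on a single place of this core: a 2.4-fold higher number from compound 1 to compound 3 (0.39 log units; beyond the scatter), modest in size but beyond the scatter. The position on the aromatic carbon para to a large group is therefore not indifferent to what it carries, a point that compound 1 and compound 2 could not settle, as they differ in how the two aryl groups are arranged and not in this substituent. On this one pair, methoxy gives the lower number and methyl the higher, but nothing in the data given bears on what lies behind that difference.

The compounds shown leave open whether a hydroxyl, an ethoxy group, a chlorine atom or a dimethylamino group at this place would give a number closer to that of compound 1 or to that of compound 3. They also leave open whether methyl in place of methoxy on compound 2, with its aryl groups arranged the other way around the core, would move the number by a similar step.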